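Fluoro to hydrogen on compound 3

The source may hold more compounds than are shown below. What is called first, only, known or untested is meant among the compounds shown, and "the series" means these compounds.

Measured in a physicochemical assay; a lower number here means a stronger inhibitor, a higher number a weaker inhibitor:
Compound 1 `CN(C)c1ccc(/C=C/C(=O)/C(CNc2ccc(F)cc2)=C(O)/C=C/c2ccc(N(C)C)cc2)cc1`: 46.9 ug/mL
Compound 2 `CN(C)c1ccc(/C=C/C(=O)/C(CNc2cccc(C(F)(F)F)c2)=C(O)/C=C/c2ccc(N(C)C)cc2)cc1`: 74.6 ug/mL
Compound 3 `CN(C)c1ccc(/C=C/c2cc(/C=C/c3ccc(N(C)C)cc3)n(-c3ccc(F)cc3)n2)cc1`: 89.1 ug/mL

In this assay, compound 3 stands at 89.1 ug/mL, within the scatter of both compound 1 and compound 2, so the three measurements do not separate it from the others. Compound 4 `CN(C)c1ccc(/C=C/c2cc(/C=C/c3ccc(N(C)C)cc3)n(-c3ccccc3)n2)cc1` has not yet been measured. It carries hydrogen in place of fluoro on an aromatic carbon.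

For the measured compounds named here, only one measured step is available as a guide: a 1.6-fold higher number from compound 1 to compound 2 (0.20 log units; within the scatter). It lies within the scatter, and it replaces 4-fluorophenyl with 3-(trifluoromethyl)phenyl on an amine nitrogen. That change sits on the core of compound 1, not on that of compound 3, so it bears only indirectly. Going by the values given here, no measured pair shows what the loss of fluoro alone does, and no change beyond the scatter is therefore expected. The expected step is a 1.1-fold lower number from compound 3 to compound 4 (0.04 log units; within the scatter), in no firm direction. For compound 4 the estimated value is 82 ug/mL, with an expected range of 45 ug/mL to 150 ug/mL.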

Compound 4, half-maximal inhibitory concentration: 72.4 ug/mL
Beside the measured number, compound 4's estimate is 1.1-fold (0.05 log units) above it, within the range that was stated.
By their numbers in this assay, from the lowest: compounds 1, 4, 2 and 3 (each within the scatter of the next).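

In this assay, for the compounds shown here, phenyl in place of 4-fluorophenyl gives a 1.2-fold lower number from compound 3 to compound 4 (0.09 log units; within the scatter), and this pair is the first to isolate the removal of fluoro, on an aromatic carbon para to a large group. The step lies within the scatter, so the fluoro at this position is not shown to matter in this assay: compound 4 keeps a number that cannot be told apart from that of compound 3. No measurement is at hand that would account for this result.

Going by these compounds, what stays open is whether any group at this position can move the number beyond the scatter, for instance an amine, a carboxylic acid or a methoxy group. The compounds shown also leave open whether such a group would act differently at another carbon of this phenyl ring.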